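Aryl thioether exchange on the shared core

A few compounds are considered here, and "the series" means these few. Any claim that something is new, unique, unknown or untested is made for them only; others in the source may bear on it.

Measured so far:
- compound 1 `CCOC(=O)c1c(CSc2ccccc2OC)n(C)c2ccc(O)cc12`; in an assay for inhibition of Polyunsaturated fatty acid 5-lipoxygenase (Homo sapiens), read by HPLC, with a stated time of 10 min (on this read-out lower numbers stand for stronger inhibition and higher numbers for weaker inhibition), compound 1 gives 2900 nM
- compound 2 `CCOC(=O)c1c(CSc2ccc(F)cc2F)n(C)c2ccc(O)cc12`; in this assay compound 2 gives 3200 nM

Compound 1 holds the smaller of the two numbers shown, but the step of a 1.1-fold higher number from compound 1 to compound 2 (0.04 log units; within the scatter) lies within the scatter, so the two compounds cannot be told apart on this read-out.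

Compound 3 `CCOC(=O)c1c(CSc2c(C)cccc2C)n(C)c2ccc(O)cc12` is not yet measured in this assay. Its change from compound 1 is 2,6-dimethylphenyl in place of 2-methoxyphenyl on a sulfur, at the sulfur whose other neighbour is a saturated chain carbon. Within the data shown here, the one measured step that bears on this position is a 1.1-fold higher number from compound 1 to compound 2 (0.04 log units; within the scatter), an exchange of the aryl group on the same sulfur that left the number essentially unchanged. Accordingly, no step beyond the scatter is expected in this assay on going to compound 3; the expected step is a 1.2-fold higher number from compound 1 to compound 3 (0.08 log units; within the scatter). For compound 3 the estimate is 3500 nM, with a range from 1500 nM to 8000 nM.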

Compound 3, half-maximal inhibitory concentration: 800 nM
Compound 3: middle estimate off by 4.4-fold (0.64 log units), on the high side; the whole stated range lies above it.
By their numbers in this assay, from the lowest: compound 3; then compounds 1 and 2 (each within the scatter of the next).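

The aryl group on this sulfur does matter in this assay, which the earlier pair, with its step inside the scatter, gave no sign of: 2,6-dimethylphenyl brings a 3.6-fold lower number from compound 1 to compound 3 (0.56 log units; beyond the scatter) and also a 4.0-fold lower number from compound 2 to compound 3 (0.60 log units; beyond the scatter) and so stands apart from both earlier aryl groups. Compound 3 thus holds the lowest number of the three, and its gain over compound 1 comes with 2-methoxyphenyl, which has one hydrogen-bond acceptor, leaving and an all-carbon aryl group of the same heavy-atom count entering. Nothing measured here accounts for this gain.

Still open, going by these compounds, is whether a 2-methylphenyl or a 2,6-dichlorophenyl group on the same sulfur would keep the lower number. Also open, on these data alone, is whether a cyclohexyl group, which has no aromatic ring, would hold it.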